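Piperidine to methylpiperazine on the ethyl chain

The compounds below may be only part of what the source reports. "The series", "measured", "known", "first", "only" and "open" are said of these compounds alone.

Compound 1, `CCN(CC)CCn1c2ccc3ccccc3c2c2nc3ccccc3nc21`, gives 180000 nM in an ADME assay on L929 cells (Mus musculus) for cytotoxicity; a higher number here means that more compound is tolerated, a lower number that less compound is tolerated. Compound 2, `c1ccc2c(c1)ccc1c2c2nc3ccccc3nc2n1CCN1CCCCC1`, reaches only a limit of this assay, reported as > 221000 nM. Compound 3, `CC1CCN(CCn2c3ccc4ccccc4c3c3nc4ccccc4nc32)CC1`, likewise reaches only a limit of this assay, reported as > 214000 nM.

Compound 2 therefore stands at the top of what this assay could report, and one other of the three values is a limit of the same kind. The step to it from the diethylamino parent is an at least 1.2-fold higher number from compound 1 to compound 2 (0.08 log units; that floor lies within the scatter), and the step to the 4-methylpiperidine analogue is an at least 1.1-fold higher number from compound 1 to compound 3 (0.07 log units; that floor lies within the scatter). Between the two limits the step is a step that the two limits leave unreadable from compound 2 to compound 3.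

Compound 4, `CN1CCN(CCn2c3ccc4ccccc4c3c3nc4ccccc4nc32)CC1`, carries 4-methylpiperazin-1-yl in place of piperidin-1-yl on a saturated chain carbon, two bonds along the chain from an aromatic nitrogen. Among the measured compounds shown here, no measured step swaps one ring for another at this position, so none bears on it directly; the nearest ones, at the limit of > 214000 nM in this assay, at which 1 of the 3 values shown sits, and (the limit of > 221000 nM in this assay, at which 1 of the 3 values shown sits), show only that changing the amine at the end of the chain left the number at or above the range the assay covers. The expected step is an at least 1.0-fold lower number from compound 2 to compound 4 (0.01 log units; that floor lies within the scatter), none beyond the scatter. Compound 4 is estimated at 215000 nM, with a range from 110000 nM to 300000 nM.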

Compound 4, half-maximal cytotoxic concentration: 21400 nM
Compound 4: the middle estimate sits 10-fold (1.00 log units) above what was measured, and the stated range ends above it.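

Within the amines on this ethyl chain, 4-methylpiperazin-1-yl is the first change to move the number in this assay beyond the scatter, giving an at least 10-fold lower number from compound 2 to compound 4 (1.01 log units; beyond the scatter) and an at least 10-fold lower number from compound 3 to compound 4 (1.00 log units; beyond the scatter). The diethylamino compound points the same way, with an 8.4-fold lower number from compound 1 to compound 4 (0.92 log units; beyond the scatter), so compound 4 stands apart from the other three, and compounds 3 and 4 differ only in the ring atom that carries the methyl. The size of the step from compound 2 remains a floor, since the value of compound 2 is only a limit: the limit of > 221000 nM in this assay, at which 1 of the 4 values shown sits.

Going by these compounds, it remains open whether other rings at this place, such as morpholin-4-yl or piperazin-1-yl without the methyl, would also lower the number. A longer chain carrying 4-methylpiperazin-1-yl is equally untested in the compounds shown.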